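Larger Aromatic Cap on the Longest Chain

This account rests on a few compounds, and the source may have more. Where it says the series, first, only, none or still open, it means among the compounds named here.

Three measured compounds share one core and differ only in the length of a saturated chain. In a functional assay on SW-620 cells (Homo sapiens) for cytotoxicity, read by MTT assay, with a stated time of 48 h (a lower number here means a stronger inhibitor, a higher number a weaker inhibitor), compound 1 `CCCCCCCCCCCCNC(=O)[C@@H](NC(=O)c1ccco1)[C@@H](C)O` gives 87500 nM and compound 2 `CCCCCCCCCCCCCCNC(=O)[C@@H](NC(=O)c1ccco1)[C@@H](C)O` gives 200000 nM, a change of a 2.3-fold higher number from compound 1 to compound 2 (0.36 log units; beyond the scatter). Compound 3 `CCCCCCCCCCCCCCCCCCNC(=O)[C@@H](NC(=O)c1ccco1)[C@@H](C)O` gives > 200000 nM, which is a limit of the assay and not a number (the limit of > 200000 nM in this assay, at which 1 of the 3 values shown sits). The steps of an at least 2.2-fold higher number from compound 1 to compound 3 (0.35 log units; beyond the scatter) and a number no lower from compound 2 to compound 3 (the limit leaves the size open) are therefore only bounds, and compound 3 stands at the edge of the measured range. Compound 4 `CCCCCCCCCCCCCCCCCCNC(=O)[C@@H](NC(=O)c1cc2ccccc2n1C)[C@@H](C)O` keeps the longest chain but carries 1-methyl-1H-indol-2-yl in place of furan-2-yl on a carbonyl carbon. Among the compounds with values here, no measured step touches this part of the molecule, so no direct guide exists. Compound 4 is expected to give 150000 nM, within 30000 nM to 600000 nM. The expected step of an at least 1.3-fold lower number from compound 3 to compound 4 (0.12 log units; that floor lies within the scatter) is small, with its direction open.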

Compound 4, half-maximal inhibitory concentration: 124000 nM
Beside the measured number, compound 4's estimate is 1.2-fold (0.08 log units) above it; the range from low to high includes it.
By their numbers in this assay, from the lowest: compounds 1, 4 and 2 (each within the scatter of the next, the first and the last beyond it).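

Every earlier step changed the saturated chain, whereas this change sits on a carbonyl carbon: in this assay, 1-methyl-1H-indol-2-yl in place of furan-2-yl gives an at least 1.6-fold lower number from compound 3 to compound 4 (0.20 log units; that floor lies within the scatter) on the longest chain. Compound 3 holds a limit and not a number: the limit of > 200000 nM in this assay, at which 1 of the 4 values shown sits.
On these data alone, compound 4 therefore gives the longest chain a readable value, but the true size of this step remains unknown.

As far as these compounds go, whether 1-methyl-1H-indol-2-yl would behave the same way on the shorter chain of compound 1 stays open. So does how a phenyl group would read on this carbonyl carbon.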